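A few compounds are considered here, and "the series" means these few. Any claim that something is new, unique, unknown or untested is made for them only; others in the source may bear on it.

Of the compounds shown here, three that share one core have been measured in an ADME assay on MT4 cells (Homo sapiens) for cytotoxicity, read by MTT assay, with a stated time of 4 days; on this read-out lower numbers stand for higher toxicity in this test and higher numbers for lower toxicity in this test. Compound 1 `Cc1cccc(Oc2nc(Nc3ccc(C#N)cc3)nc3ccccc23)c1` gives 355000 nM, compound 2 `N#Cc1ccc(Nc2nc(Oc3ccc(Br)cc3)c3ccccc3n2)cc1` gives 215000 nM, and compound 3 `Cc1cc(Br)cc(Br)c1Oc1nc(Nc2ccc(C#N)cc2)nc2ccccc12` gives 150000 nM. Compound 3 has the lowest of the three numbers; compound 2 sits nearest to it, within the scatter, while compound 1 sits furthest, and the step of a 2.4-fold lower number from compound 1 to compound 3 (0.37 log units; beyond the scatter) lies beyond the scatter.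

Compound 4 `N#Cc1ccc(Nc2nc(Oc3c(Br)cc(Br)cc3Br)c3ccccc3n2)cc1` has not yet been measured. It differs from compound 3 in one place: bromo in place of methyl on an aromatic carbon, so that the 2,4-dibromo-6-methylphenyl group becomes a 2,4,6-tribromophenyl group.

The measured steps that bear on this change all alter the ring that hangs on the oxygen. The step of a 2.4-fold lower number from compound 1 to compound 3 (0.37 log units; beyond the scatter), which put bromo groups onto that ring, gave a modest lowering of the number. The steps of a 1.7-fold lower number from compound 1 to compound 2 (0.22 log units; within the scatter) and a 1.4-fold lower number from compound 2 to compound 3 (0.16 log units; within the scatter) both stayed within the scatter. A further bromo in place of the methyl is therefore expected to give only a small lowering, most likely within the scatter, as a 1.4-fold lower number from compound 3 to compound 4 (0.13 log units; within the scatter). Compound 4 is thus estimated at 110000 nM, with a range from 50000 nM to 250000 nM.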

Compound 4, half-maximal cytotoxic concentration: 58000 nM
Compound 4: the middle estimate sits 1.9-fold (0.28 log units) above what was measured; measured number inside the range.
By their numbers in this assay, from the lowest: compound 4; then compounds 3, 2 and 1 (each within the scatter of the next, the first and the last beyond it).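

Replacing methyl with bromo at this place, on an aromatic carbon ortho to a large group, changes a single atom, yet it gives a 2.6-fold lower number from compound 3 to compound 4 (0.41 log units; beyond the scatter) in this assay, which on this read-out means higher toxicity in this test. For the compounds shown here, the 2,4,6-tribromophenyl group also sets compound 4 clearly apart from the two compounds with less bromo on this ring, with a 3.7-fold lower number from compound 2 to compound 4 (0.57 log units; beyond the scatter) and a 6.1-fold lower number from compound 1 to compound 4 (0.79 log units; beyond the scatter), so compound 4 is the one compound here whose number is lower than all the others by more than the scatter. No measurement at hand explains why this single swap moves the number by more than the scatter.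

As far as these compounds go, how a chloro, a methoxy or an amine at this same place would compare with methyl and bromo stays open, so the step cannot yet be tied to bromo in particular rather than to the loss of methyl. Going by these compounds alone, whether the swap would have a similar effect on a ring carrying different neighbouring groups also stays open, as compound 3 and compound 4 are the only pair that shows it.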